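Moving the propargyloxy group around the phenyl ring

A few compounds are considered here, and "the series" means these few. Any claim that something is new, unique, unknown or untested is made for them only; others in the source may bear on it.

Of the compounds shown here, two have been tested in an assay on BTI-TN-5B1-4 cells for inhibition of Amine oxidase [flavin-containing] A (Homo sapiens), read by fluorescence and Amplex Red, using microsomes, with a stated time of 30 min; a higher number here means a weaker inhibitor, a lower number a stronger inhibitor. Compound 1 `C#CCOc1ccc(-c2cc(-c3cccc(OCC#C)c3)nc(N)n2)cc1` gives 24100 nM, and compound 2 `C#CCOc1ccc(-c2cc(-c3ccccc3OCC#C)nc(-c3ccccc3)n2)cc1` gives 22000 nM. Compound 2 shows the lower of the two numbers, yet its gap to compound 1 is within the usual scatter of this assay, so the two cannot be told apart on potency.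

Compound 3 `C#CCOc1ccc(-c2cc(-c3cccc(OCC#C)c3)nc(-c3ccccc3)n2)cc1` is the next to be measured. It is built from compound 2 by the change (a group of 10 heavy atoms (9 carbon, 1 oxygen; one six-membered aromatic ring of carbon only) in place of a group of 10 heavy atoms (9 carbon, 1 oxygen; one six-membered aromatic ring of carbon only), on an aromatic carbon). In words: a 3-(propargyloxy)phenyl group takes the place of the group that leaves, while everything else stays as it is. For the measured compounds named here, no measured pair here shows what such a shift does, so the expectation must rest on compound 1 and compound 2 alone, which both sit at weak, similar levels.

The step from compound 2 to compound 3 is therefore expected to be small, no change at the digits printed from compound 2 to compound 3 (within the scatter), with no clear direction beyond the scatter. Compound 3 is estimated at 22000 nM, within a range from 8000 nM to 60000 nM.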

Compound 3, half-maximal inhibitory concentration: 25800 nM
Beside the measured number, compound 3's estimate is 1.2-fold (0.07 log units) below it; the measured number falls inside the stated range.
By their numbers in this assay, from the lowest: compounds 2, 1 and 3 (each within the scatter of the next).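

In this assay the swap to the 3-(propargyloxy)phenyl group gives a 1.2-fold higher number from compound 2 to compound 3 (0.07 log units; within the scatter) and so does not separate the two arrangements of this same-sized group on the shared core. For the compounds shown here, the first comparison at the other varied position, phenyl for amino, gives a 1.1-fold higher number from compound 1 to compound 3 (0.03 log units; within the scatter) and is equally unresolved, so neither single change moves the number beyond the scatter. Nothing further is available here that would account for this flat result.

All three compounds remain weak, so these compounds do not show which parts of the structure, if any, can change the number. Going by these compounds, it stays open what a methylamine or a carboxylic acid at the position of the amino group would do, or a longer chain in place of the propargyloxy group.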